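Reversing an Ester: Expected Cytotoxicity of Compound 4

This account rests on a few compounds, and the source may have more. Where it says the series, first, only, none or still open, it means among the compounds named here.

Compound 1 `CCc1cccc2c(OC)c(-c3occ(C)c3C(=O)OC)ccc12` gives 1.3 ug/mL in a functional assay on KBVIN cells (Homo sapiens) for cytotoxicity, read by MTT assay, with a stated time of 72 h; a higher number here means that more compound is needed for the effect, a lower number that less compound is needed.
Compound 2 `CCOC(=O)c1c(C)coc1-c1ccc2c(CC)cccc2c1OC` gives 1.8 ug/mL in this assay.
Compound 3 `CCc1cccc2c(OC)c(-c3occ(C)c3C(=O)NC)ccc12` reaches only a limit of > 10 ug/mL in this assay, not a number.

Among the two plain numbers, compound 2 sits together with compound 1: the step of a 1.4-fold higher number from compound 1 to compound 2 (0.14 log units; within the scatter) is within the scatter, so the two cannot be told apart. Compound 3 stands apart as a limit (the limit of > 10 ug/mL in this assay, at which 1 of the 3 values shown sits).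

The unmeasured compound 4 `CCc1cccc2c(OC)c(-c3occ(C)c3COC(C)=O)ccc12` differs from compound 2 in one place: acetoxymethyl in place of ethoxycarbonyl on an aromatic carbon.

Within the data shown here, no measured step makes this exact change. The step of a 1.4-fold higher number from compound 1 to compound 2 (0.14 log units; within the scatter) shows that changing the chain on the oxygen side of the ester hardly matters. The steps of an at least 7.6-fold higher number from compound 1 to compound 3 (0.88 log units; beyond the scatter) and an at least 5.5-fold higher number from compound 2 to compound 3 (0.74 log units; beyond the scatter) show that changing the carbonyl side costs a lot. Compound 4 keeps the carbonyl but moves it away from the ring, which is neither case. A modest loss is expected, a 1.9-fold higher number from compound 2 to compound 4 (0.29 log units; within the scatter), while a limit remains possible.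

Compound 4 is estimated at 3.5 ug/mL, in the range 1.5 ug/mL to 10 ug/mL.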

Compound 4, concentration for half-maximal effect: > 10 ug/mL
Compound 4 ended at the assay's limit (the forecaster's own chance of this, stated with the estimate: 20%); middle value at least 2.8-fold (0.45 log units) away from the limit.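

On this aromatic carbon, the way the atoms are joined matters and not only which atoms are present: acetoxymethyl and ethoxycarbonyl have the same atoms, yet replacing one with the other gives an at least 5.5-fold higher number from compound 2 to compound 4 (0.74 log units; beyond the scatter), and the matching change from the methoxycarbonyl group gives an at least 7.6-fold higher number from compound 1 to compound 4 (0.88 log units; beyond the scatter). Retaining a carbonyl within the group is therefore not enough, and only the two esters with the carbonyl on the aromatic carbon, compound 1 and compound 2, give plain numbers here, while compound 3 also has its carbonyl there but does not. Compound 4 reaches a limit, not a number, and it is the same limit as for compound 3, so the step between them cannot be read: the limit of > 10 ug/mL in this assay, at which 2 of the 4 values shown sit.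

From the compounds shown here alone, how far compound 3 and compound 4 lie past this limit stays open. So does how a carboxylic acid, a hydroxymethyl group or an ester with a longer chain on this carbon would behave in this assay.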